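Working notes: trifluoromethyl to 1,1-difluoroethyl on compound 2

The compounds below may be only part of what the source reports. "The series", "measured", "known", "first", "only" and "open" are said of these compounds alone.

Measured in a physicochemical assay for solubility, at pH 6.5; a lower number here means a less soluble compound, a higher number a more soluble compound:
- compound 1 `COCc1nc2nc(C)cc(Nc3ccc(C(F)(F)F)cc3)n2n1`: 150000 nM
- compound 2 `Cc1cc(Nc2ccc(S(F)(F)(F)(F)F)cc2)n2nc(C(F)(F)F)nc2n1`: 30000 nM

Of these two compounds, compound 2 at 30000 nM holds the lower number, and the gap to compound 1 at 150000 nM lies beyond the scatter. Among the measured compounds shown here, the pair differs in more than one place, so its gap cannot be tied to any single change, and no measured step isolates a single group.

The next compound is compound 3 `Cc1cc(Nc2ccc(S(F)(F)(F)(F)F)cc2)n2nc(C(C)(F)F)nc2n1`. It has methyl in place of fluoro on a saturated chain carbon bound to an aromatic carbon and two fluorine atoms, which reads as trifluoromethyl to 1,1-difluoroethyl (methyl in place of fluoro on a saturated chain carbon bound to an aromatic carbon and two fluorine atoms). For the measured compounds named here, the data hold no measured example of this change, so the expectation stays anchored on compound 2 at 30000 nM and its range is kept wide. In this assay, the expected step of a 1.4-fold lower number from compound 2 to compound 3 (0.13 log units; within the scatter) does not go beyond the scatter, with a slight lean toward a lower number. For compound 3 the estimated value is 22000 nM, with an expected range of 7000 nM to 60000 nM.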

Compound 3, solubility: 30000 nM
Compound 3: middle estimate off by 1.4-fold (0.13 log units), on the low side, and the stated range covers the measured number.
By their numbers in this assay, from the lowest: compounds 2 and 3 (each within the scatter of the next); then compound 1.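

In this assay, among the compounds shown here, trifluoromethyl to 1,1-difluoroethyl on the shared core gives no change at the digits printed from compound 2 to compound 3 (within the scatter), and this is the first step that isolates a single group. On a saturated chain carbon bound to an aromatic carbon and two fluorine atoms, methyl in place of fluoro therefore leaves the read-out within the scatter, an observation that rests on this one pair and on the rest of compound 2 as it stands. No measurement at hand bears on the reason for this outcome.

On these data alone, whether a hydroxyl group, an amine or a longer chain on that same carbon would also stay within the scatter remains open, as does whether the same change would read alike on a core carrying a different group on its aromatic amine portion. Compound 1 differs from compound 2 and from compound 3 in more than one place, so the gap to compound 1 remains unassigned to any single group, including the methoxymethyl group it carries.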